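One added methyl on compound 2

A few compounds are considered here, and "the series" means these few. Any claim that something is new, unique, unknown or untested is made for them only; others in the source may bear on it.

In an ADME assay on MT4 cells (Homo sapiens) for cytotoxicity, read by MTT assay, with a stated time of 4 days (a lower number here means that less compound is tolerated, a higher number that more compound is tolerated), compound 1 (`Cc1c(Cc2c(F)cccc2F)nc(N(C)C)[nH]c1=O`) gives > 89000 nM as its reading, which is a limit and not a number. Compound 2 (`Cc1c(Cc2c(F)cccc2F)nc(N2CCC(C)CC2)[nH]c1=O`) gives > 75000 nM as its reading, again a limit and not a number. Compound 2 therefore has no exact standing in this assay and sits at a limit, as compound 1 does.

Within the data shown here, the one measured step is a step that the two limits leave unreadable from compound 1 to compound 2 and it hands on no size that could be carried forward. Compound 3 (`Cc1c(C(C)c2c(F)cccc2F)nc(N2CCC(C)CC2)[nH]c1=O`) is compound 2 with a single change, methyl in place of hydrogen on a saturated chain carbon bound to two aromatic carbons and nothing else. Among the measured compounds shown here, no measured step falls at that place. The expectation thus rests on compound 2 alone, with > 75000 nM as its limit.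

The expected move is an at least 1.1-fold lower number from compound 2 to compound 3 (0.06 log units; that floor lies within the scatter) and no step beyond the scatter is foreseen in either direction, though the reading may well come back as a limit again. The estimated value for compound 3 is 65000 nM with an expected range of 25000 nM to 110000 nM for that reading.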

Compound 3, half-maximal cytotoxic concentration: 54000 nM
Estimate against measurement, compound 3: 1.2-fold (0.08 log units) above; low and high end bracket the measured number.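

Methyl in place of hydrogen on a saturated chain carbon bound to two aromatic carbons yields the only exact reading of the three compounds in this assay, and so gives this position a step with a direction. The earlier step, at the other changed place, cannot be read, whereas this change gives an at least 1.3-fold lower number from compound 2 to compound 3 (0.14 log units; that floor lies within the scatter). That figure is a floor and not a full size, because the reading of compound 2 is a limit: the limit of > 75000 nM in this assay, at which 1 of the 3 values shown sits.

The compounds shown leave open how the number would respond to an ethyl group or a hydroxyl group on that same saturated chain carbon, and so whether the size of the group entering there matters at all. They also leave open whether the same methyl would give a step of similar size in a compound that carries dimethylamino, as compound 1 does, in place of 4-methylpiperidin-1-yl.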